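Changing the group on the amide of compound 2

This account rests on a few compounds, and the source may have more. Where it says the series, first, only, none or still open, it means among the compounds named here.

In an in vitro ADME assay on microsomes from liver (Mus musculus) for pharmacokinetics, read by LC-MS, with a stated time of 10 min, tested at 1 uM (on this read-out lower numbers stand for slow clearance and higher numbers for fast clearance), compound 2 `CN1C[C@H](C(=O)Nc2cccnc2)[C@@H](c2ccc(/C=C/C(=O)Nc3ccccc3N)cc2)C1` gives 41 mL/min/kg. Among the measured compounds shown here, the only other measured compound, compound 1 `COc1ccc(NC(=O)[C@H]2CN(C)C[C@@H]2c2ccc(/C=C/C(=O)Nc3ccccc3N)cc2)cc1`, gives 54 mL/min/kg, and these two values lie within the usual scatter of each other. Compound 3 `CN1C[C@H](C(=O)Nc2ccc(Cl)cn2)[C@@H](c2ccc(/C=C/C(=O)Nc3ccccc3N)cc2)C1` is still unmeasured. It keeps the rest of compound 2 and differs in one group: 5-chloropyridin-2-yl in place of pyridin-3-yl on an amide-type nitrogen. For the measured compounds named here, one measured step bears on this place, a 1.3-fold lower number from compound 1 to compound 2 (0.12 log units; within the scatter), and it also lies within the scatter. Going by the values given here, that step exchanged a different pair of groups, so it is only a loose guide, and no measured compound carries the 5-chloropyridin-2-yl group. On this thin evidence, no shift beyond the scatter is expected in this assay, and the expected step is a 1.1-fold higher number from compound 2 to compound 3 (0.04 log units; within the scatter). The estimated clearance of compound 3 is 45 mL/min/kg, with an expected range of 23 mL/min/kg to 88 mL/min/kg.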

Compound 3, clearance: 31 mL/min/kg
Compound 3: middle estimate off by 1.5-fold (0.16 log units), on the high side; measured number inside the range.
By their numbers in this assay, from the lowest: compounds 3, 2 and 1 (each within the scatter of the next).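

In this assay, a third ring group on this amide-type nitrogen, 5-chloropyridin-2-yl, gives a 1.3-fold lower number from compound 2 to compound 3 (0.12 log units; within the scatter) and a 1.7-fold lower number from compound 1 to compound 3 (0.24 log units; within the scatter). Clearance therefore cannot be told apart among the 4-methoxyphenyl, pyridin-3-yl and 5-chloropyridin-2-yl compounds, so this position has so far tolerated a chlorine-bearing pyridine as well as the two earlier groups without a shift beyond the scatter. No measurement shown here offers an explanation for where these numbers fall.

Going from pyridin-3-yl to 5-chloropyridin-2-yl alters the ring's attachment and adds chlorine at once, and a plain pyridin-2-yl group would be needed to separate the two. On these data alone, all three groups are aromatic rings, so it remains open how clearance would respond to an open alkyl chain, or to a ring carrying an amine or a carboxylic acid.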